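The compounds below may be only part of what the source reports. "The series", "measured", "known", "first", "only" and "open" are said of these compounds alone.

In a functional assay on DU-145 cells (Homo sapiens) for cytotoxicity, read by ELISA, with a stated time of 4 days (on this read-out higher numbers stand for weaker inhibition and lower numbers for stronger inhibition), compound 1 (`Cc1ccccc1-c1cc(-c2ccoc2)cc(-c2ccc(Cl)s2)n1`) gives 18500 nM and compound 2 (`Clc1ccc(-c2cc(-c3ccoc3)cc(-c3ccccc3Cl)n2)s1`) gives 16400 nM on the same read-out. These two numbers lie within the scatter of each other, so compound 2 stands level with compound 1. Compound 3 (`Clc1ccc(-c2cc(-c3ccoc3)cc(-c3cccnc3)n2)s1`) differs from compound 2 in a single place, with pyridin-3-yl in place of 2-chlorophenyl on an aromatic carbon is the full count of that change. Among the measured compounds shown here, the one measured step is a 1.1-fold lower number from compound 1 to compound 2 (0.05 log units; within the scatter) and it exchanges only chloro for methyl, leaving the six-membered ring of carbon in place. For the measured compounds named here, it therefore offers a weak guide, since no measured step replaces that ring. In this assay the estimated step is a 1.1-fold lower number from compound 2 to compound 3 (0.04 log units; within the scatter) and no shift beyond the scatter is expected. Compound 3 is therefore expected at 15000 nM with an estimated range from 5000 nM to 40000 nM in this series.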

Compound 3, half-maximal inhibitory concentration: 18500 nM
Compound 3: the middle estimate sits 1.2-fold (0.09 log units) below what was measured, and the stated range covers the measured number.
By their numbers in this assay, from the lowest: compounds 2, 1 and 3 (each within the scatter of the next).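

In this assay, this position, on an aromatic carbon next to the ring nitrogen, now shows a change of the ring itself rather than of a small group on it: pyridin-3-yl in place of 2-chlorophenyl gives a 1.1-fold higher number from compound 2 to compound 3 (0.05 log units; within the scatter), and pyridin-3-yl in place of 2-methylphenyl gives no change at the digits printed from compound 1 to compound 3 (within the scatter). Exchanging the ring of carbon only for a ring with a nitrogen, and losing the chloro or methyl with it, thus leaves the number within the scatter in both cases. Nothing available explains why the three compounds stand level.

Going by these compounds, all three compounds carry a six-membered aromatic ring at this place, so the effect of an open-chain amine or a carboxylic acid there stays open. On these data alone, the furan-3-yl and 5-chlorothiophen-2-yl groups are also shared, so whether this level reading would hold with other groups in their places stays open too.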